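Chloro-to-fluoro exchange and cytotoxicity in a benzamide series

The compounds below may be only part of what the source reports. "The series", "measured", "known", "first", "only" and "open" are said of these compounds alone.

Compound 1 `CS(=O)(=O)Nc1ccc(NC(=O)c2ccc(C#N)cc2)cc1Cl` and compound 2 `CS(=O)(=O)Nc1ccc(NC(=O)c2cccc(C(F)(F)F)c2)cc1Cl` carry different acyl parts; the difference between the two cores is not broken down here. In an ADME assay on HEK293 cells (Homo sapiens) for cytotoxicity, read by MTT assay, with a stated time of 48 h (a higher number here means a weaker inhibitor, a lower number a stronger inhibitor), compound 1 gives > 250000 nM, which is a limit of the assay and not a number. In this assay compound 2 gives > 250000 nM, likewise only a limit. Compound 3 `CS(=O)(=O)Nc1ccc(NC(=O)c2ccc(C#N)cc2)cc1F` comes from compound 1 through (fluoro in place of chloro on an aromatic carbon). In this assay compound 3 gives > 250000 nM, again a limit rather than a number. The step that the two limits leave unreadable from compound 1 to compound 3 therefore has no readable size, since the limit of > 250000 nM in this assay, at which 3 of the 3 values shown sit, gathers every value obtained so far in this assay.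

Compound 4 `CS(=O)(=O)Nc1ccc(NC(=O)c2cccc(C(F)(F)F)c2)cc1F` has not yet been measured in this assay. It comes from compound 2 through (fluoro in place of chloro on an aromatic carbon), the same change as from compound 1 to compound 3, with the place described in identical words in both cases, so the two changes count as the same change. The expected step that the limit leaves unreadable from compound 2 to compound 4 is set beside a step that the two limits leave unreadable from compound 1 to compound 3 and rests on the fact that the limit of > 250000 nM in this assay, at which 3 of the 3 values shown sit, holds all three values, among them that of compound 2 itself. For compound 4 the estimate in this assay is 300000 nM, expected to lie between 150000 nM and 1000000 nM, most likely reported again as a limit.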

Compound 4, half-maximal inhibitory concentration: > 250000 nM
Compound 4 was reported as a limit; the forecaster's own chance of this, stated with the estimate: 85%; the middle value does not contradict the limit.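

Within the data shown here, compound 2 and compound 4 each sit at a limit of the assay in this assay, so the fluoro-for-chloro step between them cannot be read and no new step follows from this result: the limit of > 250000 nM in this assay, at which 4 of the 4 values shown sit.

The compounds shown leave open how far any of them lies from that limit, and whether fluoro in place of chloro shifts the read-out in this assay at all.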